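This account rests on a few compounds, and the source may have more. Where it says the series, first, only, none or still open, it means among the compounds named here.

Compound 1, `CCNC(=S)NCC1CCc2ccccc2N1`: 2660 nM
Compound 2, `CCC(=O)NCC1CCc2ccccc2N1Cc1ccccc1`: 36 nM

For the measured compounds named here, in a functional assay on CHO cells with melatonin receptor type 1A (Homo sapiens) as the target, read by GTPgammaS binding, with a stated time of 1 h (a lower number here means that less compound is needed, a higher number that more compound is needed for the effect), compound 2 gives 36 nM, the lowest of the two numbers measured so far, while compound 1 gives 2660 nM in this assay, a higher number that lies beyond the usual scatter. Compound 3, `CCC(=O)NCC1CCc2ccccc2N1`, has not yet been measured. It differs from compound 2 in one place: hydrogen in place of benzyl on a nitrogen on an aromatic ring in a ring. Going by the values given here, no measured pair isolates this change, and compound 1 also differs from compound 3 at its thiourea part, so the step is uncertain. A sizeable step toward a higher number is expected, a 17-fold higher number from compound 2 to compound 3 (1.22 log units; beyond the scatter). Compound 3 is estimated at 600 nM, with a range from 120 nM to 3000 nM.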

Compound 3, half-maximal effective concentration: 242 nM
The estimate for compound 3 lay 2.5-fold (0.39 log units) above the measured number, and the stated range covers the measured number.
By their numbers in this assay, from the lowest: compound 2; then compound 3; then compound 1.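

In this assay, putting hydrogen in place of the benzyl on the ring nitrogen gives a 6.7-fold higher number from compound 2 to compound 3 (0.83 log units; beyond the scatter), so the benzyl helps but the effect does not depend on it. On the amine nitrogen, the propanoyl amide in place of the thiourea part gives an 11-fold lower number from compound 1 to compound 3 (1.04 log units; beyond the scatter), so this part of the molecule also matters when the ring nitrogen carries hydrogen. Nothing here explains either step. As far as these compounds go, it remains open whether a methyl or a longer chain on the ring nitrogen would lie closer to hydrogen or to benzyl. From the compounds shown here alone, whether a thiourea and benzyl can work together on one molecule also remains open.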